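Cyclopentyl in place of 4-methoxybenzyl on an amide nitrogen

The source may report more compounds than this note shows. Statements on the series, on what has been measured and on what is new or still open speak of the compounds shown alone.

- Compound 1 `Nc1sc(-c2ccc(Cl)cc2)c(-c2ccc(Cl)cc2)c1C(=O)N1CCCCC1`: 14300 nM
- Compound 2 `CCCCNC(=O)c1c(N)sc(-c2ccc(Cl)cc2)c1-c1ccc(Cl)cc1`: 17800 nM
- Compound 3 `COc1ccc(CNC(=O)c2c(N)sc(-c3ccc(Cl)cc3)c2-c2ccc(Cl)cc2)cc1`: 29500 nM

These values come from a functional assay on PC-3 cells (Homo sapiens) for inhibition, read by sulforhodamine B assay, with a stated time of 72 h; a lower number here means a stronger inhibitor, a higher number a weaker inhibitor. The three compounds share one core and differ only in the group on the carbonyl carbon. Two steps fix the place of the 4-methoxybenzyl amide: a 1.7-fold higher number from compound 2 to compound 3 (0.22 log units; within the scatter), and a 2.1-fold higher number from compound 1 to compound 3 (0.31 log units; beyond the scatter). Compound 3 therefore cannot be told apart from compound 2, and it lies only modestly away from compound 1.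

The next compound is compound 4 `Nc1sc(-c2ccc(Cl)cc2)c(-c2ccc(Cl)cc2)c1C(=O)NC1CCCC1`. Its change is cyclopentyl in place of 4-methoxybenzyl on an amide-type nitrogen. Among the compounds with values here, no measured step makes this exact swap, so the nearest evidence comes from the other changes to this group. Replacing the 4-methoxyphenyl of the longer chain with propyl is the closest parallel, and it is the reverse of a 1.7-fold higher number from compound 2 to compound 3 (0.22 log units; within the scatter). Swapping the amine part gave a 1.2-fold higher number from compound 1 to compound 2 (0.10 log units; within the scatter). Neither step is large, so only a small move towards a lower number is expected, and none beyond the scatter. The expected change is a 1.6-fold lower number from compound 3 to compound 4 (0.21 log units; within the scatter). Compound 4 is estimated at 18000 nM, with an expected range of 9000 nM to 35000 nM.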

Compound 4, half-maximal inhibitory concentration: 21200 nM
Estimate against measurement, compound 4: 1.2-fold (0.07 log units) below; the range from low to high includes it.
By their numbers in this assay, from the lowest: compounds 1, 2, 4 and 3 (each within the scatter of the next, the first and the last beyond it).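

In this assay, cyclopentyl on the amide-type nitrogen reads the same, within the scatter, as each group it can be set against: 4-methoxybenzyl (a 1.4-fold lower number from compound 3 to compound 4 (0.14 log units; within the scatter)), butyl (a 1.2-fold higher number from compound 2 to compound 4 (0.08 log units; within the scatter)) and, one bond further out, piperidin-1-yl in place of cyclopentylamino (a 1.5-fold higher number from compound 1 to compound 4 (0.17 log units; within the scatter)). The new step also shows that a group of 5 heavy atoms, with a non-aromatic ring and no hydrogen-bond acceptor, cannot be told apart from one of 9 heavy atoms with an aromatic ring and an acceptor, so neither feature stands out as mattering at this position in these compounds. Nothing measured here explains why these groups read so alike.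

As far as these compounds go, a longer chain on the amide nitrogen ending in an amine or a carboxylic acid might or might not leave the number in this same band, and that stays open. From the compounds shown here alone, every change shown sits on the carbonyl carbon, so how much the rest of the shared core matters is also open.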